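A Second Methoxy Group on the Ring of Compound 2

The source may hold more compounds than are shown below. What is called first, only, known or untested is meant among the compounds shown, and "the series" means these compounds.

Compound 1 `O=C(N/N=C/c1cccc(Cl)c1)c1cccnc1Nc1cccc(C(F)(F)F)c1`: 61.9%
Compound 2 `COc1ccc(/C=N/NC(=O)c2cccnc2Nc2cccc(C(F)(F)F)c2)cc1`: 97.4%

Going by the values given here, in a functional assay on the whole organism (Abdomen, strain NMRI) for inhibition, with Mus musculus as the target, in the writhing test, with a stated time of 30 min, at a dose of 10 mg/kg (on this read-out lower numbers stand for less inhibition and higher numbers for more inhibition at the one dose given (going by the name of the read-out)), compound 1 gives 61.9% while compound 2 gives 97.4%, and the only measured step is a number 35.5 percentage points higher from compound 1 to compound 2 (beyond the scatter). Compound 2 therefore stands highest of the two, far above compound 1. Compound 3 `COc1ccc(/C=N/NC(=O)c2cccnc2Nc2cccc(C(F)(F)F)c2)cc1OC` differs from compound 2 by methoxy in place of hydrogen on an aromatic carbon. Among the compounds with values here, no measured step concerns a methoxy entering ortho to a methoxy group, so the large step into compound 2 offers no direct guide. Because compound 2 already gives 97.4%, near the top of the scale, no step beyond the scatter is expected for compound 3, which is estimated at 90% (70% to 100%), a step of a number 7.4 percentage points lower from compound 2 to compound 3 (within the scatter).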

Compound 3, a percentage reported as inhibition, in the whole organism at one dose (the size of the read-out at that dose, not a potency): 80.7%
Estimate against measurement, compound 3: 9.3 percentage points above; the range from low to high includes it.
By their numbers in this assay, from the lowest: compound 1; then compound 3; then compound 2.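

In this assay, the step from 4-methoxyphenyl to 3,4-dimethoxyphenyl gives a number 16.7 percentage points lower from compound 2 to compound 3 (beyond the scatter), so a second methoxy on this ring lowers the effect beyond the scatter rather than preserving it. The 3,4-dimethoxyphenyl group still compares well with 3-chlorophenyl, giving a number 18.8 percentage points higher from compound 1 to compound 3 (beyond the scatter). Nothing measured here accounts for these differences. The compounds shown leave open whether a hydroxyl group or an amine on that aromatic carbon would preserve the effect of compound 2. They also leave open how an ethoxy group, with its longer chain, would fare there.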